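The compounds below may be only part of what the source reports. "The series", "measured", "known", "first", "only" and "open" are said of these compounds alone.

Working notes on the series. In a functional assay on B16 cells (Mus musculus) for inhibition, with a stated time of 72 h (on this read-out lower numbers stand for stronger inhibition and higher numbers for weaker inhibition), compound 1 (`S=C1NCCN1Cc1ccccc1`) gives > 10000 nM, which is a limit of the assay. Compound 2 (`Cc1ccc(CN2CCNC2=S)cc1`) gives 4800 nM. Compound 3 (`S=C1NCCCN1Cc1ccccc1`) gives > 10000 nM, also a limit of the assay. Compound 3 therefore has no number and stands at the limit of > 10000 nM in this assay, at which 2 of the 3 values shown sit.

Compound 4 (`S=C1NCCCN1Cc1ccc(Cl)cc1`) differs from compound 3 by chloro in place of hydrogen on an aromatic carbon. In words, this is chloro in place of hydrogen on an aromatic carbon. Within the data shown here, only one measured step bears on this change: an at least 2.0-fold lower number from compound 1 to compound 2 (0.31 log units; beyond the scatter), with methyl in place of hydrogen on an aromatic carbon. That step is a single case, it was taken on the core of compound 1 rather than that of compound 3, and its size is known only as a minimum. A modest move towards a lower number in this assay is therefore expected, and a reading at the assay limit remains possible. The expected step is an at least 1.8-fold lower number from compound 3 to compound 4 (0.25 log units; that floor lies within the scatter). Compound 4 is estimated at 5500 nM, with an expected range of 2000 nM to 14000 nM.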

Compound 4, half-maximal inhibitory concentration: 2400 nM
For compound 4 the middle estimate is 2.3-fold (0.36 log units) above the measured one; the measured number falls inside the stated range.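

On the core of compound 3, chloro in place of hydrogen on an aromatic carbon gives an at least 4.1-fold lower number from compound 3 to compound 4 (0.61 log units; beyond the scatter) in this assay. Together with an at least 2.0-fold lower number from compound 1 to compound 2 (0.31 log units; beyond the scatter), this shows the same kind of move away from the assay limit on a second core, here with chloro rather than methyl, and no compound shown goes against it. The size of the new step remains a minimum, because compound 3 has only a limit of the assay and no number: the limit of > 10000 nM in this assay, at which 2 of the 4 values shown sit.

Methyl and chloro have not been compared on one shared core, so the two steps cannot be ranked against each other. Going by these compounds, what a methoxy group, a nitrile or an amine would give at this place remains open, as does the effect of chloro on another carbon of the aromatic ring.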